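Acylguanidines: taking one acyl group off compound 2

This account rests on a few compounds, and the source may have more. Where it says the series, first, only, none or still open, it means among the compounds named here.

Measured in a functional assay on SK-MEL-28 cells (Homo sapiens) for inhibition, read by MTT assay, with a stated time of 72 h; on this read-out lower numbers stand for stronger inhibition of growth and higher numbers for weaker inhibition of growth:
- compound 1 `CC(C)=CC(=O)NC(=N)N`: > 100000 nM (a limit of the assay, not a number)
- compound 2 `CC(C)=CCC/C(C)=C/C(=O)NC(=N)NC(=O)C=C(C)C`: 53400 nM

Among the measured compounds shown here, compound 2, at 53400 nM, holds the only true number so far. Compound 1 is recorded only as a limit, > 100000 nM. For the measured compounds named here, with one number and one limit, there is no ranking to speak of and no measured step to draw on.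

The next compound for this assay is compound 3 `CC(C)=CCC/C(C)=C/C(=O)NC(=N)N`. Relative to compound 2, it has hydrogen in place of (2-methylprop-1-en-1-yl)carbonyl on an amine nitrogen.

Going by the values given here, with no measured step available, the expectation is anchored on compound 2 at 53400 nM and is correspondingly loose. The estimated step of a 1.3-fold lower number from compound 2 to compound 3 (0.13 log units; within the scatter) is expected to stay within the usual scatter, so no clear direction is expected. A report as a limit alone also remains possible for compound 3. The expected value for compound 3 is 40000 nM, with an estimated range of 13000 nM to 100000 nM.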

Compound 3, concentration for 50% growth inhibition: 56300 nM
Estimate against measurement, compound 3: 1.4-fold (0.15 log units) below; the range from low to high includes it.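

In this assay, hydrogen in place of (2-methylprop-1-en-1-yl)carbonyl on the amine nitrogen gives a 1.1-fold higher number from compound 2 to compound 3 (0.02 log units; within the scatter), so the second acyl group is shown for the first time to be dispensable at this position, with compound 2 and compound 3 lying within the scatter of each other. The other measured change, 3-methylbut-2-en-1-yl in place of hydrogen on a saturated chain carbon bound to a double-bonded chain carbon, gives an at least 1.7-fold lower number from compound 1 to compound 3 (0.24 log units; that floor lies within the scatter), and with that floor inside the scatter it supports no claim that the longer acyl chain improves the number. Compound 1 is recorded only as a limit of the assay, > 100000 nM, so this step has a floor and no measured size: the limit of > 100000 nM in this assay, at which 1 of the 3 values shown sits.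

Open, on these data alone, is whether any other group on this nitrogen, such as an acyl group carrying an amine or a carboxylic acid, would move the number beyond the scatter. Also open, as far as these compounds go, is how a still longer chain, or a saturated chain in place of the 3-methylbut-2-en-1-yl end, would read in this assay.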